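The source may hold more compounds than are shown below. What is called first, only, known or untested is meant among the compounds shown, and "the series" means these compounds.

Measured so far in a functional assay on MCF7 cells (Homo sapiens) for antiproliferative activity, read by MTT assay, with a stated time of 72 h; on this read-out lower numbers stand for stronger inhibition and higher numbers for weaker inhibition:
Compound 1 `CCC/C=C/C(=O)Nc1cccc(Oc2nc(Nc3ccc(OC)cc3)nc3c2CSCC3)c1`: > 50000 nM
Compound 2 `CC/C=C/C(=O)Nc1cccc(Oc2nc(Nc3ccc(OC)nc3)nc3c2CSCC3)c1`: 31500 nM

The entry for compound 1, > 50000 nM, is a limit and not a number. For the measured compounds named here, compound 2, at 31500 nM, holds the only actual number so far.

Next in line is compound 3 `CCC/C=C/C(=O)Nc1cccc(Oc2nc(Nc3ccc(OC)nc3)nc3c2CSCC3)c1`, not yet measured. It departs from compound 2 by methyl in place of hydrogen on a saturated chain carbon, two bonds along the chain from a double-bonded chain carbon, so that ethyl becomes propyl.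

Going by the values given here, no measured step is available to size this change. In this assay no shift beyond the usual scatter is expected, with any drift toward weaker inhibition. The expected step is a 1.1-fold higher number from compound 2 to compound 3 (0.06 log units; within the scatter). For compound 3 the estimated value is 36000 nM, with an expected range of 15000 nM to 65000 nM.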

Compound 3, half-maximal inhibitory concentration: 26800 nM
Compound 3: the middle estimate sits 1.3-fold (0.13 log units) above what was measured; the range from low to high includes it.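

In this assay, the change from ethyl to propyl on a saturated chain carbon, two bonds along the chain from a double-bonded chain carbon, gives a 1.2-fold lower number from compound 2 to compound 3 (0.07 log units; within the scatter), which is the only measured size for this change and shows no shift beyond the scatter. Compound 3 also pairs with compound 1 at a second place, where 6-methoxypyridin-3-yl in place of 4-methoxyphenyl on a nitrogen on an aromatic ring gives an at least 1.8-fold lower number from compound 1 to compound 3 (0.27 log units; that floor lies within the scatter). The entry for compound 1 is a limit and not a number, so this step is only a floor, and its full size cannot be read: the limit of > 50000 nM in this assay, at which 1 of the 3 values shown sits.

From the compounds shown here alone, whether a longer chain or a terminal amine at this position would move the number beyond the scatter remains open. Also open, going by these compounds, is how far the step from 4-methoxyphenyl to 6-methoxypyridin-3-yl extends past its floor.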